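The source may report more compounds than this note shows. Statements on the series, on what has been measured and on what is new or still open speak of the compounds shown alone.

Working notes on the series. In a functional assay on A-375 cells (Homo sapiens) for antiproliferative activity, read by MTT assay, with a stated time of 48 h (a higher number here means a weaker inhibitor, a lower number a stronger inhibitor), compound 1 (`COC1=CC(=O)N(C(=O)/C=C/[C@H](C)NC(=O)[C@H](CC(C)C)N(C)C)[C@@H]1Cc1ccccc1`) returns only a limit of the assay (> 100000 nM) and not a number. Compound 2 (`CC[C@H](C)[C@H](NC(=O)OCc1ccccc1)C(=O)N[C@@H](CC(C)C)C(=O)N[C@@H](CC(C)C)C(=O)N[C@@H](C)/C=C/C(=O)N1C(=O)C=C(OC)[C@@H]1c1cn(C(=O)OC(C)(C)C)c2ccccc12`) likewise returns only a limit (> 100000 nM) and has no number of its own. The series therefore stands entirely at the limit of > 100000 nM in this assay, at which 2 of the 2 values shown sit, and gives no measured gradient to work from.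

Compound 3 (`CC[C@H](C)[C@H](NC(=O)OCc1ccccc1)C(=O)N[C@@H](CC(C)C)C(=O)N[C@@H](CC(C)C)C(=O)N[C@@H](C)/C=C/C(=O)N1C(=O)C=C(OC)[C@@H]1c1c[nH]c2ccccc12`) keeps the peptide chain and shared core of compound 2, with hydrogen in place of tert-butoxycarbonyl on an aromatic nitrogen of a five-membered aromatic ring with 1 nitrogen. For the measured compounds named here, no measured step bears on this change, so any expectation of its size is weakly founded. In this assay the expected move is modest and towards a stronger inhibitor, and another result at the limit would be no surprise. The estimated change is an at least 2.0-fold lower number from compound 2 to compound 3 (0.30 log units; that floor lies within the scatter) in size. For compound 3 the estimated half-maximal inhibitory concentration is 50000 nM with an expected range from 10000 nM to 100000 nM in this assay.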

Compound 3, half-maximal inhibitory concentration: > 100000 nM
Compound 3 was reported as a limit; the forecaster's own chance of this, stated with the estimate: 55%; middle value at least 2.0-fold (0.30 log units) from the limit.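

In this assay compound 3 gives > 100000 nM, a limit of the assay and not a number. Compound 2 is also reported only as a limit, so no step can be read between compound 2 and compound 3. The compounds shown leave open whether any structural change in this series gives a measured number, as the series stands wholly at: the limit of > 100000 nM in this assay, at which 3 of the 3 values shown sit.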